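Acylation of a Pyrazoline Nitrogen: Expected Edema Inhibition

A few compounds are considered here, and "the series" means these few. Any claim that something is new, unique, unknown or untested is made for them only; others in the source may bear on it.

The measured compounds and their values:
compound 1, `COc1ccc(C2=NNC(c3c(Cl)cccc3Cl)C2)cc1OC`, 26%
compound 2, `COc1ccc(C2=NNC(c3c(Cl)cccc3Cl)C2)cc1`, 54%
compound 3, `COc1ccc(C2=NN(C(=O)CO[N+](=O)[O-])C(c3ccco3)C2)cc1OC`, 32%

The readings come from a functional assay on the whole organism (strain albino) for inhibition, with Rattus norvegicus as the target, read by paw edema, with stated times of 30 min and 1 h, at a dose of 100 mg/kg by the oral route; a lower number here means less inhibition, a higher number more inhibition at the dose given (going by the name of the read-out). Among the three measured compounds, compound 2 gives the highest number, 54%. Its nearest neighbour is compound 3, whose value, 32%, lies beyond the scatter below it. Going by the values given here, compound 1 gives 26%, and the one single-place step known, a number 28 percentage points higher from compound 1 to compound 2 (beyond the scatter), is a modest rise for hydrogen in place of methoxy on an aromatic carbon.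

Compound 4, `COc1ccc(C2=NN(C(=O)CO[N+](=O)[O-])C(c3c(Cl)cccc3Cl)C2)cc1`, differs from compound 2 in one place: ((nitrooxy)methyl)carbonyl in place of hydrogen on an amine nitrogen in a ring. Among the compounds with values here, no measured step isolates this change. Compound 3 carries the same ((nitrooxy)methyl)carbonyl group, but it also differs from compound 1 in the ring substituent. Compound 3 gives 32%. Set against the number of compound 1, this value cannot be read as a step. With no direct evidence, the expected step of a number 6 percentage points lower from compound 2 to compound 4 (within the scatter) is small or none beyond the scatter. Compound 4 is therefore estimated at 48%, within a range of 28% to 68%.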

Compound 4, a percentage reported as inhibition, in the whole organism at one dose (the size of the read-out at that dose, not a potency): 34%
Estimate against measurement, compound 4: 14 percentage points above; measured number inside the range.
By their numbers in this assay, from the lowest: compounds 1, 3 and 4 (each within the scatter of the next); then compound 2.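

In this assay, going by these compounds alone, ((nitrooxy)methyl)carbonyl in place of hydrogen on the amine nitrogen in the ring gives a number 20 percentage points lower from compound 2 to compound 4 (beyond the scatter), the first step that can be read at this position. The earlier step concerned only a methoxy group on an aromatic carbon, whereas this one shows that the read-out also responds to a change at the ring nitrogen, with compound 4 still giving 34% at the dose tested. No measurement shown here accounts for the lower number.

Whether the step belongs to the carbonyl alone or to the nitrooxy end remains open, since a plain acetyl group on the same nitrogen is not among the compounds shown. Also open, as far as these compounds go, is how a longer chain between the carbonyl and the nitrooxy group would read in this assay.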